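Thiourea aryl halogen swap: bromo to iodo

The source may hold more compounds than are shown below. What is called first, only, known or untested is meant among the compounds shown, and "the series" means these compounds.

In a functional assay on MKN-74 cells (Homo sapiens) for antiproliferative activity, with a stated time of 24 h (on this read-out lower numbers stand for stronger inhibition and higher numbers for weaker inhibition), compound 3 `NC(=O)c1c(NC(=O)c2ccccc2Cl)sc2c1CCN(C(=S)Nc1ccccc1Br)C2` gives 10800 nM, the lowest of the three numbers. Compound 2 `NC(=O)c1c(NC(=O)c2ccccc2Cl)sc2c1CCN(C(=S)Nc1ccccc1F)C2` gives 12600 nM; the two lie within the scatter of each other, so no order between them is claimed. Compound 1 `NC(=O)c1c(NC(=O)c2ccccc2Cl)sc2c1CCN(Cc1ccc([N+](=O)[O-])cc1)C2` gives 31500 nM, separated by a 2.9-fold lower number from compound 1 to compound 3 (0.46 log units; beyond the scatter) and a 2.5-fold lower number from compound 1 to compound 2 (0.40 log units; beyond the scatter), both beyond the scatter. Compound 4 `NC(=O)c1c(NC(=O)c2ccccc2Cl)sc2c1CCN(C(=S)Nc1ccccc1I)C2` differs from compound 3 by iodo in place of bromo on an aromatic carbon. Among the compounds with values here, the only measured step of the same kind, a halogen exchange at that aromatic carbon, was a 1.2-fold lower number from compound 2 to compound 3 (0.07 log units; within the scatter), within the scatter; the ring-halogen choice has so far left this read-out flat. No step beyond the scatter is therefore expected. Compound 4 is estimated at 10000 nM, range 5000 nM to 20000 nM. The expected step is a 1.1-fold lower number from compound 3 to compound 4 (0.03 log units; within the scatter).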

Compound 4, half-maximal inhibitory concentration: 2630 nM
Compound 4: middle estimate off by 3.8-fold (0.58 log units), on the high side, outside the stated range (below it).
By their numbers in this assay, from the lowest: compound 4; then compounds 3 and 2 (each within the scatter of the next); then compound 1.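

In this assay the halogen on this aromatic carbon does matter: iodo gives a 4.1-fold lower number from compound 3 to compound 4 (0.61 log units; beyond the scatter) and a 4.8-fold lower number from compound 2 to compound 4 (0.68 log units; beyond the scatter) even though the fluoro and bromo compounds stay within the scatter of each other. With iodo in place, the change of the whole group on the amine nitrogen in a ring reads a 12-fold lower number from compound 1 to compound 4 (1.08 log units; beyond the scatter) as the largest step in the set. No measurement offered here accounts for the iodo result.

On these data alone, whether a methyl or methoxy group on that carbon would match iodo stays open. So does whether iodo keeps this step on another carbon of the ring.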